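Replacing Fluoro with Methoxy on Compound 3

The source may report more compounds than this note shows. Statements on the series, on what has been measured and on what is new or still open speak of the compounds shown alone.

In a functional assay on HSC-2 cells (Homo sapiens) for cytotoxicity, with a stated time of 24 h (on this read-out lower numbers stand for higher toxicity in this test and higher numbers for lower toxicity in this test), compound 1 (`O=C1/C(=C/c2ccccc2)CCC/C1=C\c1ccccc1[N+](=O)[O-]`) gives 3800 nM, compound 2 (`COc1ccc(/C=C2\CCC/C(=C\c3cccc([N+](=O)[O-])c3)C2=O)cc1`) gives 4800 nM and compound 3 (`O=C1/C(=C/c2ccc(F)cc2)CCC/C1=C\c1ccc([N+](=O)[O-])cc1`) gives 19000 nM. Compound 3 thus holds the highest number of the three, beyond the scatter from both others. Compound 4 (`COc1ccc(/C=C2\CCC/C(=C\c3ccc([N+](=O)[O-])cc3)C2=O)cc1`) departs from it at one place: methoxy in place of fluoro on an aromatic carbon. Methoxy stands in place of fluoro on an aromatic carbon. Going by the values given here, no measured pair shows this change alone. Compound 2, which also carries 4-methoxyphenyl, stands at 4800 nM, though it differs from compound 4 elsewhere. A moderate step downward, a 2.4-fold lower number from compound 3 to compound 4 (0.38 log units; beyond the scatter), is therefore expected. The estimated value for compound 4 is 8000 nM, within a range of 3000 nM to 20000 nM.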

Compound 4, half-maximal cytotoxic concentration: > 400000 nM
Compound 4 gave a limit, no number; the forecaster's own chance of this, stated with the estimate: 3%; middle value at least 50-fold (1.69 log units) from the limit.
By their numbers in this assay, from the lowest: compounds 1 and 2 (each within the scatter of the next); then compound 3. At a limit, above all of these: compound 4.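

Compound 3 and compound 4 give the first single-place comparison, and exchanging fluoro for methoxy on an aromatic carbon, para to a large group, gives an at least 21-fold higher number from compound 3 to compound 4 (1.32 log units; beyond the scatter) in this assay. The result for compound 4 is a limit of the assay, not a number: the limit of > 400000 nM in this assay, at which 1 of the 4 values shown sits. Compound 2, which also carries 4-methoxyphenyl, gives 4800 nM, so that group does not bring such a result wherever it occurs.

The compounds shown leave open how an amine, a carboxylic acid or a longer alkoxy chain would read at this position.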